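Ester to Ethylamide at the Carbonyl of Compound 1

The source may hold more compounds than are shown below. What is called first, only, known or untested is meant among the compounds shown, and "the series" means these compounds.

Compound 1, `CCOC(=O)c1sc2nc(SC)nc(-c3cccc(OC)c3)c2c1N`: 1.5%
Compound 2, `COc1cccc(-c2nc(SC)nc3sc(C(=O)NNC(C)(C)C)c(N)c23)c1`: 6.4%

In a functional assay on HEK293 cells for agonist activity at Thyrotropin receptor (Homo sapiens), read by cAMP accumulation (a lower number here means a smaller maximal response, a higher number a larger maximal response), compound 1 gives 1.5%. Compound 2 gives 6.4% in this assay, and the step of a number 4.9 percentage points higher from compound 1 to compound 2 (within the scatter) stays within the scatter, so the two compounds sit together at the low end of the scale, neither separated from the other.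

Compound 3, `CCNC(=O)c1sc2nc(SC)nc(-c3cccc(OC)c3)c2c1N`, differs from compound 1 in one place: ethylamino in place of ethoxy on a carbonyl carbon. Among the compounds with values here, the only measured step that bears on this change is the one from compound 1 to compound 2, where the same ethoxy on the same carbonyl carbon was exchanged for a nitrogen-linked group and the maximal response moved a number 4.9 percentage points higher from compound 1 to compound 2 (within the scatter), within the scatter. Ethylamino is a smaller exchange of the same kind, so no step beyond the scatter is expected, a number 2.5 percentage points higher from compound 1 to compound 3 (within the scatter).

Compound 3 is therefore estimated at 4% in this assay, with a range from 0% to 14%.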

Compound 3, largest response reached (reported as efficacy), in percent of the reference or control that the assay uses: 2.3%
Compound 3: middle estimate off by 1.7 percentage points, on the high side; low and high end bracket the measured number.
By their numbers in this assay, from the lowest: compounds 1, 3 and 2 (each within the scatter of the next).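

In this assay, the exchange of ethoxy for ethylamino on the carbonyl carbon comes out as a number 0.8 percentage points higher from compound 1 to compound 3 (within the scatter) and so adds a second nitrogen-linked group that cannot be told apart from the ester at this position. The exchange of (tert-butyl)amino for ethyl on the amide-type nitrogen reads as a number 4.1 percentage points lower from compound 2 to compound 3 (within the scatter) and shows that the two nitrogen-linked groups cannot be told apart from each other either, so all three compounds remain together at the low end of the scale. Nothing at hand explains why these exchanges leave the maximal response unseparated.

From the compounds shown here alone, what remains open is whether any group on this carbonyl carbon can separate a compound from this low cluster, as a carboxylic acid, a primary amide or an ethylamide with a longer chain in place of the ethyl might or might not do. Also open, going by these compounds, is whether the response depends on this position at all or on other parts of the shared core, which stay the same in all three compounds.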